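A few compounds are considered here, and "the series" means these few. Any claim that something is new, unique, unknown or untested is made for them only; others in the source may bear on it.

In an assay on COS-7 cells for agonist activity at Free fatty acid receptor 1 (Homo sapiens), read by scintillation counting and inositol phosphate accumulation, with a stated time of 90 min (a lower number here means that less compound is needed, a higher number that more compound is needed for the effect), compound 1 `Cc1cc(=O)oc2cc(OCc3nc(N)nc(Nc4ccc(Cl)cc4)n3)ccc12` gives 32500 nM and compound 2 `Cc1cccc(Nc2nc(N)nc(COc3ccc4c(C)cc(=O)oc4c3)n2)c1` gives 1780 nM; compound 2 therefore stands at the lowest of the two numbers shown, separated from compound 1 by the single measured step, an 18-fold lower number from compound 1 to compound 2 (1.26 log units; beyond the scatter).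

Compound 3 `Cc1cc(Nc2nc(N)nc(COc3ccc4c(C)cc(=O)oc4c3)n2)ccc1Cl` differs from compound 2 by chloro in place of hydrogen on an aromatic carbon. Going by the values given here, the one step that bears on this is an 18-fold lower number from compound 1 to compound 2 (1.26 log units; beyond the scatter), in which the chloro-bearing aryl on the ring nitrogen gave the higher number and the methyl-bearing aryl the lower. Among the compounds with values here, compound 3 carries both substituents on that ring, a combination no measured pair covers. An upward move in this assay is expected since compound 1 with its chloro gave 32500 nM, but a smaller one than that step because the methyl of compound 2 with 1780 nM is retained. The expected step is a 2.0-fold higher number from compound 2 to compound 3 (0.29 log units; within the scatter). For compound 3 the estimate is 3500 nM, within 900 nM to 14000 nM.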

Compound 3, half-maximal effective concentration: 240 nM
Beside the measured number, compound 3's estimate is 15-fold (1.16 log units) above it; the whole stated range lies above it.
By their numbers in this assay, from the lowest: compound 3; then compound 2; then compound 1.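

In this assay, chloro on the aromatic carbon ortho to a methyl group and para to a large group gives a 7.4-fold lower number from compound 2 to compound 3 (0.87 log units; beyond the scatter) and so lowers the number once the methyl is present, which the comparison of 4-chlorophenyl with 3-methylphenyl alone gave no sign of. Read from the other side, methyl in place of hydrogen on the chloro-bearing ring gives a 140-fold lower number from compound 1 to compound 3 (2.13 log units; beyond the scatter) and makes the 4-chloro-3-methylphenyl of compound 3 the lowest of the three numbers. Nothing on hand accounts for how the two groups combine on this ring.

Going by these compounds, whether the lower number needs chloro itself, or would also follow with bromo or trifluoromethyl on that carbon, stays open. So does whether an ethyl or a methoxy group in place of the methyl would keep it.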